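Adding a chloro to a limit-bound compound

This account rests on a few compounds, and the source may have more. Where it says the series, first, only, none or still open, it means among the compounds named here.

Measured in a functional assay on A549 cells (Homo sapiens) for inhibition, read by MTT assay, with a stated time of 72 h; on this read-out higher numbers stand for weaker inhibition and lower numbers for stronger inhibition:
Compound 1 `C=C(c1ccc(Cl)c(Cl)c1Cl)C1COC2(CCCC2)OO1`: 690 nM
Compound 2 `C=C(c1cc(Cl)cc(Cl)c1OCc1ccccc1)C1COC2(CCCC2)OO1`: 2070 nM
Compound 3 `C=C(c1ccc(Cl)c(Cl)c1)C1COC(C)(C)OO1`: > 100000 nM

Compound 3 gives > 100000 nM, which is a limit of this assay and not a number. Going by the values given here, no number therefore marks how weak compound 3 is, and no step between measured compounds offers a size to borrow.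

Compound 4 `C=C(c1ccc(Cl)c(Cl)c1Cl)C1COC(C)(C)OO1` follows from compound 3 with chloro in place of hydrogen on an aromatic carbon, ortho to a chloro group and to a large group: chloro in place of hydrogen on an aromatic carbon.

Compound 1 has the same substitution on its aromatic ring as compound 4 but differs elsewhere on the core, and the expectation leans on compound 1 at 690 nM. A move toward stronger inhibition is therefore expected, although compound 4 may still meet the limit. The expected move is an at least 3.3-fold lower number from compound 3 to compound 4 (0.52 log units; beyond the scatter), and this size is uncertain. For compound 4 the estimated value is 30000 nM, within an expected range of 4000 nM to 100000 nM.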

Compound 4, half-maximal inhibitory concentration: 52100 nM
The estimate for compound 4 lay 1.7-fold (0.24 log units) below the measured number; the range from low to high includes it.
By their numbers in this assay, from the lowest: compound 1; then compound 2; then compound 4. At a limit, above all of these: compound 3.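

In this assay, with chloro in place of hydrogen on an aromatic carbon, ortho to a chloro group and to a large group, compound 4 gives 52100 nM. Compound 3 has only a limit and not a number. The change reads as an at least 1.9-fold lower number from compound 3 to compound 4 (0.28 log units; that floor lies within the scatter), so it is a floor and the true size of the step may be small or much larger. The step can be given only as a floor because compound 3 stands at a limit and not at a number: the limit of > 100000 nM in this assay, at which 1 of the 4 values shown sits.

The compounds shown do not tell whether fluoro, methoxy or an amine at this position would give a number as well. They also leave open how much the same chloro counts on the core of compound 1, since no partner lacking it is shown.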